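The source may hold more compounds than are shown below. What is called first, only, known or untested is meant among the compounds shown, and "the series" means these compounds.

Measured compounds:
compound 1, `CCCc1cc(N)c2cc(NC(=O)/C=C/c3ccc(CC)cc3)ccc2n1`, 160 nM
compound 2, `CCCc1cc(N)c2cc(NC(=O)/C=C/c3ccc(Cl)c(Cl)c3)ccc2n1`, 990 nM

In a functional assay on HEK293 cells for activation of melanin-concentrating hormone receptor 1 (Homo sapiens), read by inositol phosphate accumulation (on this read-out higher numbers stand for an effect only at larger amounts of compound and lower numbers for an effect already at smaller amounts), compound 1 gives 160 nM and compound 2 gives 990 nM. Among the compounds with values here, compound 2 thus stands highest of the two numbers; the nearest is compound 1, and the single measured step, a 6.2-fold higher number from compound 1 to compound 2 (0.79 log units; beyond the scatter), is beyond the scatter and modest in size.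

Compound 3, `CCCc1cc(N)c2cc(NC(=O)/C=C/c3ccc(Cl)cc3Cl)ccc2n1`, is the next member. It differs from compound 2 by 2,4-dichlorophenyl in place of 3,4-dichlorophenyl on a double-bonded chain carbon bound to a double-bonded chain carbon; the two share every atom and the same count of chlorines on the ring, only joined differently.

Within the data shown here, no measured step bears directly on this change. Among the measured compounds shown here, the only step known, a 6.2-fold higher number from compound 1 to compound 2 (0.79 log units; beyond the scatter), concerns the exchange of one ring substituent pattern for another with different atoms and says nothing about shifting one chlorine to another place on the same ring. With no guide from the data, no step beyond the scatter is expected from compound 2 to compound 3 in this assay, in either direction, and the uncertainty is correspondingly wide.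

Compound 3 is therefore estimated at 1000 nM in this assay, with a range from 300 nM to 3500 nM, which corresponds to an expected step of a 1.0-fold higher number from compound 2 to compound 3 (0.00 log units; within the scatter).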

Compound 3, half-maximal effective concentration: 904 nM
Compound 3: the middle estimate sits 1.1-fold (0.04 log units) above what was measured, and the stated range covers the measured number.
By their numbers in this assay, from the lowest: compound 1; then compounds 3 and 2 (each within the scatter of the next).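

In this assay, moving the chlorines from the 3,4-dichlorophenyl to the 2,4-dichlorophenyl pattern on a double-bonded chain carbon bound to a double-bonded chain carbon gives a 1.1-fold lower number from compound 2 to compound 3 (0.04 log units; within the scatter), so at this position the two arrangements cannot be told apart. The exchange of 4-ethylphenyl for 2,4-dichlorophenyl gives a 5.7-fold higher number from compound 1 to compound 3 (0.75 log units; beyond the scatter), a modest step in the same direction as a 6.2-fold higher number from compound 1 to compound 2 (0.79 log units; beyond the scatter), so among these three compounds the separation lies between 4-ethylphenyl and the two dichlorophenyl groups, not between the two chlorine arrangements. Nothing at hand accounts for either result.

Going by these compounds, whether the lower number of compound 1 depends on the ethyl group itself or on the absence of the chlorines stays open, and 4-chlorophenyl or plain phenyl at this position would help separate the two. Also open, on these data alone, is how far the trend at this position extends to other groups, such as 4-methoxyphenyl or a longer 4-butylphenyl, in this assay.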